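Methyl in Place of Methoxy on the Shared Core

The source may hold more compounds than are shown below. What is called first, only, known or untested is meant among the compounds shown, and "the series" means these compounds.

Compound 1 `COc1ncnc2c1c(-c1ccsc1)cn2[C@@H]1O[C@H](CO)[C@@H](O)[C@H]1O`: 130 nM
Compound 2 `COc1ncnc2c1c(-c1cc3ccccc3o1)cn2[C@@H]1O[C@H](CO)[C@@H](O)[C@H]1O`: 4470 nM

In a functional assay on HL-60 cells (Homo sapiens) for antiproliferative activity, read by XTT assay, with a stated time of 72 h (on this read-out lower numbers stand for stronger inhibition and higher numbers for weaker inhibition), compound 1 gives the lowest of the two numbers; its nearest neighbour is compound 2, separated by a 34-fold higher number from compound 1 to compound 2 (1.54 log units; beyond the scatter). Compound 3 `Cc1ncnc2c1c(-c1ccsc1)cn2[C@@H]1O[C@H](CO)[C@@H](O)[C@H]1O` differs from compound 1 by methyl in place of methoxy on an aromatic carbon.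

For the measured compounds named here, that single measured step concerns the thiophen-3-yl group and does not touch the methoxy, so no measured step bears on this change. No direction is therefore expected; compound 3 is estimated to show a 1.5-fold higher number from compound 1 to compound 3 (0.19 log units; within the scatter), a step within the scatter. The estimate for compound 3 is 200 nM, with a range of 50 nM to 1200 nM.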

Compound 3, half-maximal inhibitory concentration: 350 nM
Compound 3: middle estimate off by 1.8-fold (0.24 log units), on the low side; low and high end bracket the measured number.
By their numbers in this assay, from the lowest: compound 1; then compound 3; then compound 2.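

In this assay, methyl in place of methoxy gives a 2.7-fold higher number from compound 1 to compound 3 (0.43 log units; beyond the scatter), a modest step beyond the scatter. For the compounds shown here, this is the first measured sign that the number responds to the group at this position of the shared core, and not only to the thiophen-3-yl site. No supporting measurement accounts for the step. The compounds shown leave open how an amine or an ethoxy group at this position would compare with methoxy. They also leave open whether the methyl step would be similar with 1-benzofuran-2-yl in place of thiophen-3-yl.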